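Indanyl in Place of Alkylphenyl: Expected Effect on Binding

The source may report more compounds than this note shows. Statements on the series, on what has been measured and on what is new or still open speak of the compounds shown alone.

Compound 1: `O=C(O)CCNC(=O)c1ccc(CN(c2ccc(Cl)cc2)c2nc(-c3ccc(C(F)(F)F)cc3)cs2)cc1` gives 649 nM
Compound 2: `Cc1cc(N(Cc2ccc(C(=O)NCCC(=O)O)cc2)c2nc(-c3ccc(C(F)(F)F)cc3)cs2)ccc1C(C)C` gives 633 nM

Both measured compounds were tested in an in vitro assay on BHK cells for displacement of a labelled ligand from gastric inhibitory polypeptide receptor (Homo sapiens), read by scintillation proximity assay; a lower number here means a stronger inhibitor, a higher number a weaker inhibitor. Going by the values given here, compound 2 stands at the lowest of the two numbers, but its only neighbour, compound 1, sits so close that the two cannot be told apart: the step of a 1.0-fold lower number from compound 1 to compound 2 (0.01 log units; within the scatter) lies within the scatter. That step exchanged a 4-chlorophenyl for a 4-isopropyl-3-methylphenyl on the nitrogen attached to the aromatic ring, and the readout did not move.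

Compound 3 `O=C(O)CCNC(=O)c1ccc(CN(c2ccc3c(c2)CCC3)c2nc(-c3ccc(C(F)(F)F)cc3)cs2)cc1` is not yet measured. It differs from compound 2 by 2,3-dihydro-1H-inden-5-yl in place of 4-isopropyl-3-methylphenyl on a nitrogen on an aromatic ring. Among the compounds with values here, the one measured step that touches this position, from compound 1 to compound 2, shows that a sizeable change of the group on that nitrogen left the number unchanged, so for compound 3 a step of a 1.0-fold higher number from compound 2 to compound 3 (0.00 log units; within the scatter) is expected, that is, nothing beyond the scatter. Accordingly, compound 3 is estimated at 640 nM in this assay, with a plausible range from 300 nM to 1400 nM.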

Compound 3, half-maximal inhibitory concentration: 1100 nM
Estimate against measurement, compound 3: 1.7-fold (0.24 log units) below, within the range that was stated.
By their numbers in this assay, from the lowest: compounds 2, 1 and 3 (each within the scatter of the next).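

In this assay, closing the substituents on the phenyl ring into a five-membered non-aromatic ring gives a 1.7-fold higher number from compound 2 to compound 3 (0.24 log units; within the scatter) and a 1.7-fold higher number from compound 1 to compound 3 (0.23 log units; within the scatter) when compared with the other group at this position. The earlier pair showed only that 4-chlorophenyl and 4-isopropyl-3-methylphenyl could not be told apart, whereas 2,3-dihydro-1H-inden-5-yl extends this to a group with a second, fused ring, and all three numbers still lie within the scatter of one another. No other measurement bears on this result, so the data offer no explanation for it.

Going by these compounds, all three groups on the nitrogen consist of a carbon-only aromatic ring with chlorine or carbon substituents, so it remains open whether a pyridine ring, or a phenyl ring carrying an amine or a carboxylic acid, would move the number beyond the scatter. The rest of the molecule stays the same in these compounds, so they also leave open whether the same tolerance would hold if another part of it, such as the trifluoromethyl group, were replaced.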